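The compounds below may be only part of what the source reports. "The series", "measured", "known", "first", "only" and "open" are said of these compounds alone.

Compound 1 `Clc1ccc(-c2cc(-c3ccoc3)cc(-c3ccco3)n2)s1`: 4740 nM
Compound 2 `Cc1ccsc1-c1cc(-c2ccc(Cl)o2)cc(-c2cccc(Cl)c2)n1`: 18800 nM

In a functional assay on MCF7 cells (Homo sapiens) for cytotoxicity, read by ELISA, with a stated time of 4 days (on this read-out lower numbers stand for stronger inhibition and higher numbers for weaker inhibition), compound 2 has the higher of the two numbers, 18800 nM, while compound 1 is lower at 4740 nM, a gap beyond the scatter. Compound 3 `Cc1ccsc1-c1cc(-c2ccc(Cl)o2)cc(-c2cccnc2)n1` has pyridin-3-yl in place of 3-chlorophenyl on an aromatic carbon. Among the measured compounds shown here, no measured pair shows this change, so any forecast in this assay is uncertain. A small move towards a lower number is expected, probably within the scatter: a 1.6-fold lower number from compound 2 to compound 3 (0.19 log units; within the scatter). The estimated value for compound 3 is 12000 nM, with an expected range from 4000 nM to 35000 nM.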

Compound 3, half-maximal inhibitory concentration: 5810 nM
The estimate for compound 3 lay 2.1-fold (0.32 log units) above the measured number; measured number inside the range.
By their numbers in this assay, from the lowest: compounds 1 and 3 (each within the scatter of the next); then compound 2.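

In this assay, placing pyridin-3-yl instead of 3-chlorophenyl on the aromatic carbon next to the ring nitrogen gives a 3.2-fold lower number from compound 2 to compound 3 (0.51 log units; beyond the scatter) as a step beyond the scatter. Among the compounds shown here, this is the first sign that the number responds to the group at this position. No measurement shown here accounts for the shift.

From the compounds shown here alone, whether the chlorine leaving or the ring nitrogen entering matters more stays open, and plain phenyl would help separate the two. How an amine or a carboxylic acid on that ring would fare is also unknown.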